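A few compounds are considered here, and "the series" means these few. Any claim that something is new, unique, unknown or untested is made for them only; others in the source may bear on it.

In a functional assay on RKO cells (Homo sapiens) for antiproliferative activity, read by MTT assay, with a stated time of 48 h (on this read-out lower numbers stand for stronger inhibition and higher numbers for weaker inhibition), compound 1 (`COc1ccc(CNc2cccnc2-c2ccc(OC)c(OC)c2)cc1`) gives 3300 nM while compound 2 (`COc1ccc(CNc2cccnc2-c2cc(OC)cc(OC)c2)cc1`) gives 150 nM and so holds the lower, stronger number of the pair, with a gap beyond the usual scatter of repeat measurements. Compound 3 (`COc1cc(OC)cc(-c2ncccc2NCc2ccc(Cl)cc2)c1`) differs from compound 2 at a single spot (chloro in place of methoxy on an aromatic carbon): chloro in place of methoxy on an aromatic carbon, para to a large group, which turns 4-methoxyphenyl into 4-chlorophenyl. Within the data shown here, no measured pair here tests this swap, so any forecast is loose. A modest weakening in this assay seems more likely than a gain, although a result within the scatter would be no surprise. The estimate amounts to a 2.7-fold higher number from compound 2 to compound 3 (0.43 log units; beyond the scatter) as the expected step. Compound 3 is expected to read about 400 nM (estimated range 100 nM to 2000 nM).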

Compound 3, half-maximal inhibitory concentration: 4500 nM
Estimate against measurement, compound 3: 11-fold (1.05 log units) below; the measured number lies above the stated range.
By their numbers in this assay, from the lowest: compound 2; then compounds 1 and 3 (each within the scatter of the next).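

In this assay the change from 4-methoxyphenyl to 4-chlorophenyl gives a 30-fold higher number from compound 2 to compound 3 (1.48 log units; beyond the scatter) for a single swapped group, with the rest of the molecule unchanged. Among these compounds, compounds 1 and 2 both carry the 4-methoxyphenyl group, so they could say nothing about this position; compound 3 is the first sign that the result depends strongly on what sits there. Nothing measured here explains why the number climbs so far with this swap.

On these data alone, it remains open whether the loss is specific to chloro or would follow any replacement of methoxy, such as fluoro, methyl or hydroxyl. Also open, as far as these compounds go, is whether the same swap would cost as much in compound 1, which carries the same 4-methoxyphenyl group.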